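Permeability notes: cyclohexyl for 4-cyanobenzyl on the core

A few compounds are considered here, and "the series" means these few. Any claim that something is new, unique, unknown or untested is made for them only; others in the source may bear on it.

Measured so far in an ADME assay for permeability, using PAMPA, with a stated time of 30 min, at pH 7.4; on this read-out lower numbers stand for lower permeability and higher numbers for higher permeability:
compound 1 `COc1cccc(CNCCCNc2ccnc3cc(Cc4ccc(C#N)cc4)ccc23)c1O` gives 23 10^-6 cm/s
compound 2 `N#Cc1ccc(Cc2ccc3c(NCCCNCc4ccco4)ccnc3c2)cc1` gives 23 10^-6 cm/s

Compound 1 stands level with compound 2 at the digits shown. Among the compounds with values here, the only measured step, no change at the digits printed from compound 1 to compound 2 (within the scatter), is a change at the saturated chain carbon bound to an amine nitrogen, with no movement beyond the scatter.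

Compound 3 `COc1cccc(CNCCCNc2ccnc3cc(C4CCCCC4)ccc23)c1O` is to be measured in this assay. It differs from compound 1 as follows: cyclohexyl in place of 4-cyanobenzyl on an aromatic carbon. Within the data shown here, this change sits on an aromatic carbon of the shared core, not at the chain end varied between compound 1 and compound 2, so no measured step tests this position directly. Among the measured compounds shown here, the single step available, no change at the digits printed from compound 1 to compound 2 (within the scatter), shows the read-out tolerating a group swap elsewhere without change, and nothing among the measured compounds points to a direction for this one.

For compound 3 the expected step of no change at the digits printed from compound 1 to compound 3 (within the scatter) is therefore none beyond the scatter. Compound 3 is estimated at 23 10^-6 cm/s, with a range from 11 10^-6 cm/s to 46 10^-6 cm/s.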

Compound 3, apparent permeability: 23 10^-6 cm/s
The estimate for compound 3 equals the measured number at the digits printed; the measured number falls inside the stated range.
By their numbers in this assay, from the lowest: compounds 1, 2 and 3 (each within the scatter of the next).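

Working notes on the core position: the aromatic carbon of the shared core now has a reading of its own in this assay, whereas compound 1 and compound 2 differ only at the chain end. Cyclohexyl in place of 4-cyanobenzyl gives no change at the digits printed from compound 1 to compound 3 (within the scatter). For this pair the read-out therefore stays level across a change in which the entering group has fewer heavy atoms, a non-aromatic ring in place of an aromatic one, no triple bond and no hydrogen-bond acceptor. No supporting measurement speaks to why the read-out holds level here.

As far as these compounds go, whether the same holds for a carboxylic acid or an amine on this aromatic carbon remains open, since the two groups seen there are both built from a six-membered carbon ring. Also open, from the compounds shown here alone, are a longer chain between the core and the far amine nitrogen, and whether cyclohexyl on the core would read the same alongside the furan-2-yl chain end.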